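The compounds below may be only part of what the source reports. "The series", "measured", "known", "first", "only" and "open" are said of these compounds alone.

The measured compounds:

Compound 1, `COc1cc2occ(-c3csc4ccccc34)c(=O)c2c(OC)c1OC`: 640 nM
Compound 2, `CCOc1c(OC)cc2occ(-c3csc4ccccc34)c(=O)c2c1OC`: 4800 nM
Compound 3, `CCOc1ccc(O)c(C(=O)/C=C/c2csc3ccccc23)c1`: 5400 nM

All three were tested in a functional assay on A549 cells (Homo sapiens) for antiproliferative activity, read by sulforhodamine B assay, with a stated time of 72 h; a lower number here means a stronger inhibitor, a higher number a weaker inhibitor. Compound 4, `CC(C)Oc1ccc(O)c(C(=O)/C=C/c2csc3ccccc23)c1`, has not yet been measured there.

Compound 1 and compound 2 share one core and differ in a single place, (methyl in place of hydrogen on a saturated chain carbon bound to an oxygen on an aromatic ring). That change gave a 7.5-fold higher number from compound 1 to compound 2 (0.88 log units; beyond the scatter), a step toward weaker inhibition.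

Compound 3 carries a different core; how the core of compound 3 differs from the core of compound 1 is not broken down here. Its value and that of compound 1 show a wide gap between them, whereas its value and that of compound 2 lie close together.

Compound 4 is related to compound 3 by methyl in place of hydrogen on a saturated chain carbon bound to an oxygen on an aromatic ring and a saturated chain carbon. For the measured compounds named here, this is the same kind of change as the one from compound 1 to compound 2, though not the same: in compound 1 the carbon that receives the methyl is bound to an oxygen on an aromatic ring, while in compound 3 it is bound to an oxygen on an aromatic ring and a saturated chain carbon. A step in the same direction is expected because the earlier change produced a 7.5-fold higher number from compound 1 to compound 2 (0.88 log units; beyond the scatter). The two cores differ, and here the change reads ethyl to isopropyl rather than methyl to ethyl, and a somewhat smaller step is expected: a 2.2-fold higher number from compound 3 to compound 4 (0.35 log units; beyond the scatter). For compound 4 the estimated value in this assay is 12000 nM, with a likely range from 4000 nM to 40000 nM.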

Compound 4, half-maximal inhibitory concentration: 6400 nM
The estimate for compound 4 lay 1.9-fold (0.27 log units) above the measured number; measured number inside the range.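

In this assay, the new step is a 1.2-fold higher number from compound 3 to compound 4 (0.07 log units; within the scatter), so on the core of compound 3 the exchange of ethoxy for isopropoxy moves the number by no more than the scatter of the assay. Placing a methyl on a saturated chain carbon bound to an oxygen on an aromatic ring therefore did not carry the same size of step from one core to the other: the same change on two cores in this assay, a 7.5-fold higher number (0.88 log units; beyond the scatter) from compound 1 to compound 2 and a 1.2-fold higher number (0.07 log units; within the scatter) from compound 3 to compound 4, 6.3-fold (0.80 log units) apart, beyond the scatter of two such steps This does not show that the core alone sets the size of the step, as the two pairs differ in the chain as well as in the core, the earlier one reading methyl to ethyl and the new one ethyl to isopropyl, and each core is represented by a single pair.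

The compounds shown leave open whether the same ethyl to isopropyl change would give a large or a small step on the core of compound 1, and whether methyl to ethyl would do so on the core of compound 3. They also leave open how either core would respond to a longer chain, such as butoxy, or to a chain ending in an amine at this oxygen.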